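Swapping a Methyl for Chlorine on an Inactive Core

The source may hold more compounds than are shown below. What is called first, only, known or untested is meant among the compounds shown, and "the series" means these compounds.

Compound 1 `COc1cc2c(Nc3nc4ccc(C(=O)Nc5c(C)cccc5C)cc4s3)ncnc2cc1OCCCN1CCCCC1` was tested in a functional assay on HCT-116 cells (Homo sapiens) for cytotoxicity, read by WST assay, with a stated time of 72 h; a higher number here means a weaker inhibitor, a lower number a stronger inhibitor. In this assay compound 1 gives > 100000 nM, which is a limit of the assay and not a number. Compound 2 `COc1cc2c(Nc3nc4ccc(C(=O)Nc5c(C)cccc5C)cc4s3)ncnc2cc1OCCCN1CCCCC1C`, made by placing a methyl in place of hydrogen on a saturated ring carbon, gives > 100000 nM in this assay, also a limit. The step that the two limits leave unreadable from compound 1 to compound 2 cannot be read, because of the limit of > 100000 nM in this assay, at which 2 of the 2 values shown sit. Compound 3 `COc1cc2c(Nc3nc4ccc(C(=O)Nc5c(C)cccc5Cl)cc4s3)ncnc2cc1OCCCN1CCCCC1` differs from compound 1 by chloro in place of methyl on an aromatic carbon. Among the compounds with values here, the only measured step changes a different part of the molecule, and both values shown are limits, so no size or direction for the new change can be read from them. Compound 3 is therefore expected to stay at the limit, the estimated step being a number no higher from compound 1 to compound 3 (the limit leaves the size open). For compound 3 the expected value in this assay is 100000 nM, with a range from 30000 nM to 300000 nM.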

Compound 3, half-maximal inhibitory concentration: 23400 nM
For compound 3 the middle estimate is 4.3-fold (0.63 log units) above the measured one; measured number below the stated range.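

Chloro in place of methyl on an aromatic carbon, ortho to a large group, is the first change here to give a readable move in this assay, with an at least 4.2-fold lower number from compound 1 to compound 3 (0.63 log units; beyond the scatter). This shows that the 2,6-dimethylphenyl end of compound 1 is a place where a change can bring the number down, something the methyl on the saturated ring carbon could not show. The step from compound 1 to compound 2 cannot be read, and the new step gives only a smallest size, not a full one, because compound 1 stands at a limit: the limit of > 100000 nM in this assay, at which 2 of the 3 values shown sit.

Still open, from the compounds shown here alone, is whether a methoxy, a bromo or a second chloro at this end would lower the number further. Also open, going by these compounds, is what the methyl on the saturated ring carbon would do on compound 3, whose value is not a limit.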